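Half-life notes: from compound 3 to compound 4

This account rests on a few compounds, and the source may have more. Where it says the series, first, only, none or still open, it means among the compounds named here.

In an ADME assay on the whole organism (strain Sprague-Dawley) for metabolic stability, with Rattus norvegicus as the target, read by LC-MS (on this read-out higher numbers stand for a longer-lived compound and lower numbers for a shorter-lived compound), compound 1 (`CC(Oc1nn(-c2ccccc2F)c2ccc(F)cc12)C(=O)N1CCOCC1`) gives 2 h and compound 2 (`O=C1NCCN1CCOc1nn(-c2ccccc2F)c2ccc(F)cc12`) gives 0.4 h on the same read-out. Compound 3 (`O=C1N(c2ccncc2)CCN1c1cccc2c1cnn2-c1ccccc1F`) gives 1.3 h which lies within the scatter of compound 1 and clearly above compound 2.

Compound 4 (`O=C1N(Cc2ncco2)CCN1c1cccc2c1cnn2-c1ccccc1F`) keeps the core of compound 3 and alters one group ((1,3-oxazol-2-yl)methyl in place of pyridin-4-yl on an amide-type nitrogen in a ring) with (1,3-oxazol-2-yl)methyl in place of pyridin-4-yl on an amide-type nitrogen in a ring.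

Going by the values given here, no two measured compounds differ in one place only, so no measured step speaks directly to this change. Among the compounds with values here, the only guide is the span of the three values, and compound 3 is the sole measured compound that carries this substitution site. In this assay the expectation is therefore no step beyond the scatter, with a slight lean towards a shorter-lived compound. That lean is a judgement and not a measured trend. The estimate amounts to an expected 1.4-fold lower number from compound 3 to compound 4 (0.16 log units; within the scatter) and it should stay within the scatter. For compound 4 the estimated half-life is 0.9 h with an expected range from 0.4 h to 2 h on repeat measurement.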

Compound 4, half-life: 1.1 h
Compound 4: the middle estimate sits 1.2-fold (0.09 log units) below what was measured; the measured number falls inside the stated range.
By their numbers in this assay, from the lowest: compound 2; then compounds 4, 3 and 1 (each within the scatter of the next).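

In this assay, the exchange at this site gives a 1.2-fold lower number from compound 3 to compound 4 (0.07 log units; within the scatter), so on this read-out pyridin-4-yl and (1,3-oxazol-2-yl)methyl on an amide-type nitrogen in a ring cannot be told apart. Going by these compounds alone, this is the first step that isolates one place, and it shows that a one-six-membered aromatic ring with 1 hetero atom can give way to a methyl-linked five-membered aromatic ring with 2 hetero atoms without a half-life change beyond the scatter, with the shared core and the number of heavy atoms unchanged. No measurement at hand explains why the half-life holds across this change.

One pair cannot separate the ring exchange from the added methyl link, and pyridin-4-ylmethyl or a directly attached 1,3-oxazol-2-yl would be needed to tell those two parts apart. Going by these compounds, whether an amine or a carboxylic acid on a longer chain at this nitrogen would move the half-life beyond the scatter also remains open.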